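A few compounds are considered here, and "the series" means these few. Any claim that something is new, unique, unknown or untested is made for them only; others in the source may bear on it.

Measured in a functional assay on HeLa cells (Homo sapiens) for antiproliferative activity, read by spectrophotometry, with a stated time of 2 days (a lower number here means a stronger inhibitor of growth, a higher number a weaker inhibitor of growth), so far:

- Compound 1 `Cc1ccc(Nc2ncc(C(F)(F)F)c(N3Cc4cccc(N(C)S(C)(=O)=O)c4C3)n2)c(Cl)c1` gives 10900 nM 
- Compound 2 `COc1cc(Nc2ncc(C(F)(F)F)c(N3Cc4cccc(N(C)S(C)(=O)=O)c4C3)n2)c(OC)cc1Cl` gives 16500 nM 
- Compound 3 `CN(c1cccc2c1CN(c1nc(Nc3ccc(C(F)(F)F)cc3)ncc1C(F)(F)F)C2)S(C)(=O)=O` gives > 30000 nM (a limit of the assay, not a number)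

For compound 3 there is only the limit of > 30000 nM in this assay, at which 1 of the 3 values shown sits, and no exact value.

Compound 4 `COc1cc(Nc2ncc(C(F)(F)F)c(N3Cc4cccc(N(C)S(C)(=O)=O)c4C3)n2)cc(OC)c1` differs from compound 3 in one group, with 3,5-dimethoxyphenyl in place of 4-(trifluoromethyl)phenyl on a nitrogen on an aromatic ring and the rest of the structure unchanged.

All three measured steps change this same place. The step of a 1.5-fold higher number from compound 1 to compound 2 (0.18 log units; within the scatter) shows no real change between two quite different groups. The steps of an at least 2.7-fold higher number from compound 1 to compound 3 (0.43 log units; beyond the scatter) and an at least 1.8-fold higher number from compound 2 to compound 3 (0.25 log units; that floor lies within the scatter) both end at a limit, so they give only minimum sizes. Compound 2 at 16500 nM is the closest guide, since its group is also a dimethoxyphenyl. Compound 4 is therefore expected to fall near compound 2 in this assay and to inhibit growth somewhat more strongly than compound 3 does, although another limit remains quite possible. Going by the values given here, with only three compounds as a basis, this expectation is loose.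

The estimated step is an at least 1.7-fold lower number from compound 3 to compound 4 (0.24 log units; that floor lies within the scatter) and its true size stays uncertain.

For compound 4 the estimate is 17000 nM with an expected range from 7000 nM to 30000 nM in this assay.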

Compound 4, concentration for 50% growth inhibition: 7000 nM
Compound 4: the middle estimate sits 2.4-fold (0.39 log units) above what was measured; measured number inside the range.
By their numbers in this assay, from the lowest: compounds 4, 1 and 2 (each within the scatter of the next, the first and the last beyond it). At a limit, above all of these: compound 3.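

In this assay, the place on a nitrogen on an aromatic ring now gives its first step between two exact numbers that lies beyond the scatter: with a 2.4-fold lower number from compound 2 to compound 4 (0.37 log units; beyond the scatter) the value moves even though both groups carry two methoxy groups, so having a dimethoxyphenyl group does not by itself set the number. Against that, with a 1.6-fold lower number from compound 1 to compound 4 (0.19 log units; within the scatter) the 3,5-dimethoxyphenyl group and the 2-chloro-4-methylphenyl group cannot be told apart here, so quite different groups can still read alike at this place. The change from 4-(trifluoromethyl)phenyl gives an at least 4.2-fold lower number from compound 3 to compound 4 (0.63 log units; beyond the scatter) and this is only a minimum size, as compound 3 is a limit of the assay and not a number: the limit of > 30000 nM in this assay, at which 1 of the 4 values shown sits.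

The compounds shown leave open how a phenyl ring with a single methoxy group, or one carrying an amine or a carboxylic acid, would read in this assay at this place. Going by these compounds, all four compounds also share the rest of the structure, so it stays unknown whether these differences would hold on another core.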